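Urea aryl replacement by methylisoxazole amide in the series

The source may report more compounds than this note shows. Statements on the series, on what has been measured and on what is new or still open speak of the compounds shown alone.

Compound 1 `Cc1ccc(NC(=O)Nc2cc(Cl)cc(Cl)c2)cc1NC(=O)c1ccccc1` is the reference point here. In a functional assay on A375P cells (Homo sapiens) for antiproliferative activity (a lower number here means a stronger inhibitor, a higher number a weaker inhibitor), compound 1 gives 259 nM, the lowest of the two numbers shown. Compound 2 `CC(=O)c1cccc(NC(=O)Nc2ccc(C)c(NC(=O)c3ccccc3)c2)c1` gives 9800 nM. Compound 3 `Cc1ccc(NC(=O)Nc2ccc3c(c2)OCCO3)cc1NC(=O)c1ccccc1` is recorded only as a limit of the assay, > 30000 nM. Both measured steps away from compound 1 change the group on the amide-type nitrogen of the urea and both lose strongly: a 38-fold higher number from compound 1 to compound 2 (1.58 log units; beyond the scatter) and an at least 110-fold higher number from compound 1 to compound 3 (2.06 log units; beyond the scatter); the latter rests on (the limit of > 30000 nM in this assay, at which 1 of the 3 values shown sits).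

Compound 4 `Cc1cc(C(=O)Nc2ccc(C)c(NC(=O)c3ccccc3)c2)no1` goes further than either, as the whole (3,5-dichlorophenyl)amino group on the carbonyl carbon is exchanged: 5-methyl-1,2-oxazol-3-yl in place of (3,5-dichlorophenyl)amino on a carbonyl carbon. The steps to compound 2 and compound 3 show that removing the 3,5-dichlorophenyl alone already costs a large amount, so an upward step, likely large, is expected in this assay from compound 1 to compound 4: a 58-fold higher number from compound 1 to compound 4 (1.76 log units; beyond the scatter). Compound 4 is therefore estimated at 15000 nM, within a range of 3000 nM to 40000 nM, with a real chance that only a limit is reported.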

Compound 4, half-maximal inhibitory concentration: > 30000 nM
Compound 4 gave a limit, no number; the forecaster's own chance of this, stated with the estimate: 40%; middle value at least 2.0-fold (0.30 log units) away from the limit.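

In this assay the replacement of the whole (3,5-dichlorophenyl)amino group by 5-methyl-1,2-oxazol-3-yl gives an at least 110-fold higher number from compound 1 to compound 4 (2.06 log units; beyond the scatter), so a large loss also follows when the change reaches beyond the aryl group. Unlike compound 2 and compound 3, compound 4 has lost the urea itself, and its five-membered aromatic ring with 2 hetero atoms does not bring back the activity of compound 1. Compound 4 is recorded only as a limit, the same one as compound 3, so the two cannot be ordered: the limit of > 30000 nM in this assay, at which 2 of the 4 values shown sit.

Compound 4 changes the ring and removes the amino nitrogen in one step, so the share of each in the loss remains unresolved. Open too, as far as these compounds go, is whether 5-methyl-1,2-oxazol-3-yl or 3,5-bis(trifluoromethyl)phenyl on the amide-type nitrogen of the urea would retain activity.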